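Adding a Nitro Group to the Phenoxy Ring of Compound 3

The source may report more compounds than this note shows. Statements on the series, on what has been measured and on what is new or still open speak of the compounds shown alone.

Compound 1, `COc1cc2c(cc1CC=C(C)C)/C(=N/NC(N)=O)C[C@@H](c1ccc(O)cc1)O2`: 77%
Compound 2, `COc1ccc([C@@H]2C/C(=N/OCc3cn(-c4ccccc4CO)nn3)c3cc(CC=C(C)C)c(OC)cc3O2)cc1`: 100%
Compound 3, `COc1cc2c(cc1CC=C(C)C)C(=O)C[C@@H](c1ccc(Oc3ccccc3)cc1)O2`: 46%

In a functional assay on A549 cells (Homo sapiens) for inhibition, read by sulforhodamine B assay, with a stated time of 48 h, tested at 50 uM (a lower number here means less inhibition of growth, a higher number more inhibition of growth at the concentration tested), compound 3 gives 46%, the lowest of the three numbers. Compound 1 gives 77% and compound 2 gives 100%, each beyond the scatter above compound 3. Compound 4, `COc1cc2c(cc1CC=C(C)C)C(=O)C[C@@H](c1ccc(Oc3cccc([N+](=O)[O-])c3)cc1)O2`, differs from compound 3 in a single place: nitro in place of hydrogen on an aromatic carbon. For the measured compounds named here, no measured pair shows this change, so the numbers give no direct guide to its size. The step is expected to be small, a number 4 percentage points higher from compound 3 to compound 4 (within the scatter), no larger than the scatter and with no clear direction. Compound 4 is therefore expected to give about 50%, with a range from 25% to 75%.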

Compound 4, percent growth inhibition at one concentration: 37%
For compound 4 the middle estimate is 13 percentage points above the measured one; the range from low to high includes it.
By their numbers in this assay, from the lowest: compounds 4 and 3 (each within the scatter of the next); then compound 1; then compound 2.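

In this assay, for the compounds shown here, nitro in place of hydrogen on the aromatic carbon of the phenoxy ring gives a number 9 percentage points lower from compound 3 to compound 4 (within the scatter), the first direct reading of this change. At this place, meta to a large group, the 3-nitrophenoxy group therefore leaves the number inside the usual scatter of the parent phenoxy group. Nothing available bears on why the step has this size.

On these data alone, whether an amine or a carboxylic acid at this same carbon would move the number beyond the scatter stays open. So does the outcome of nitro elsewhere on the phenoxy ring.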